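Replacing the Methoxyphenyl Group: What to Expect for Compound 3

The source may report more compounds than this note shows. Statements on the series, on what has been measured and on what is new or still open speak of the compounds shown alone.

Measured so far:
compound 1, `COc1ccc(-c2nnc(SCCn3c([N+](=O)[O-])cnc3C)o2)cc1`, gives 5800 nM in a functional assay on HepG2 cells (Homo sapiens) for cytotoxicity, read by MTT assay, with a stated time of 48 h; a higher number here means a weaker inhibitor, a lower number a stronger inhibitor
compound 2, `Cc1ncc([N+](=O)[O-])n1CCSc1nnc(-c2ccc(N)nc2)o1`, gives 9400 nM

Compound 1 holds the smaller of the two numbers, but the step of a 1.6-fold higher number from compound 1 to compound 2 (0.21 log units; within the scatter) lies within the scatter, so compound 1 and compound 2 cannot be separated on these data.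

Compound 3, `Cc1ncc([N+](=O)[O-])n1CCSc1nnc(-c2ccncc2)o1`, differs from compound 1 by pyridin-4-yl in place of 4-methoxyphenyl on an aromatic carbon. For the measured compounds named here, the only measured step that bears on this change is the one from compound 1 to compound 2, which also replaced the 4-methoxyphenyl group at the same place with a six-membered aromatic ring carrying ring nitrogen, and that step was a 1.6-fold higher number from compound 1 to compound 2 (0.21 log units; within the scatter), within the scatter. On that basis compound 3 is expected to show no step beyond the scatter, that is a 1.3-fold higher number from compound 1 to compound 3 (0.11 log units; within the scatter). For compound 3 the estimate is therefore 7500 nM, with a range from 3500 nM to 16000 nM.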

Compound 3, half-maximal inhibitory concentration: 14800 nM
For compound 3 the middle estimate is 2.0-fold (0.30 log units) below the measured one; the measured number falls inside the stated range.
By their numbers in this assay, from the lowest: compounds 1, 2 and 3 (each within the scatter of the next, the first and the last beyond it).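

In this assay, for the compounds shown here, the change to pyridin-4-yl gives a 2.6-fold higher number from compound 1 to compound 3 (0.41 log units; beyond the scatter), the first step at this place on the ring that lies beyond the scatter, although it is modest, so the group held here can shift the number. The step of a 1.6-fold higher number from compound 2 to compound 3 (0.20 log units; within the scatter) stays within the scatter, so compound 2 and compound 3 cannot be separated, and compound 2 remains within the scatter of compound 1 as well. Nothing available here accounts for the step from the 4-methoxyphenyl group to pyridin-4-yl.

The compounds shown leave open whether the step follows from the ring nitrogen or from the loss of the methoxy group. A plain phenyl group at this place would bear on that question, and a pyridin-3-yl group would show whether the position of the ring nitrogen matters.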